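The compounds below may be only part of what the source reports. "The series", "measured", "known", "first", "only" and "open" are said of these compounds alone.

Measured so far:
- Compound 1, `CC1CC1C(=O)N1CCc2nc(C#Cc3ccccc3)sc2C1`: 9.4 nM
- Compound 2, `COC1CC(C(=O)N2CCc3nc(C#Cc4ccccc4)sc3C2)C1`: 640 nM
- Compound 3, `O=C(C1CCCCC1)N1CCc2nc(C#Cc3ccccc3)sc2C1`: 167 nM

All three share a core and differ only in the group on the carbonyl carbon. In an assay on HEK293 cells for positive allosteric modulation of metabotropic glutamate receptor 5 (Homo sapiens), read by FLIPR, with a stated time of 1 h (a higher number here means that more compound is needed for the effect, a lower number that less compound is needed), compound 1 gives 9.4 nM, the lowest of the three numbers. Compound 3 stands second highest in this assay: the step of an 18-fold higher number from compound 1 to compound 3 (1.25 log units; beyond the scatter) separates it from compound 1, and the step of a 3.8-fold lower number from compound 2 to compound 3 (0.58 log units; beyond the scatter) separates it from compound 2, so it lies nearer to compound 2 than to compound 1.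

Compound 4, `O=C(C1CCC(F)(F)CC1)N1CCc2nc(C#Cc3ccccc3)sc2C1`, keeps the core and the ring of compound 3, with one change: 4,4-difluorocyclohexyl in place of cyclohexyl on a carbonyl carbon. For the measured compounds named here, none of the measured steps tests this kind of change. The steps of a 68-fold higher number from compound 1 to compound 2 (1.83 log units; beyond the scatter) and an 18-fold higher number from compound 1 to compound 3 (1.25 log units; beyond the scatter) swap one ring for another of different size, and the step of a 3.8-fold lower number from compound 2 to compound 3 (0.58 log units; beyond the scatter) exchanges a methoxy-bearing four-membered ring for a bare six-membered ring. Since the six-membered ring itself is kept here, the step of a 1.2-fold higher number from compound 3 to compound 4 (0.08 log units; within the scatter) is expected to stay small, in no firm direction. Compound 4 is therefore estimated at 200 nM in this assay, with a range from 60 nM to 700 nM.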

Compound 4, half-maximal effective concentration: 70 nM
Compound 4: the middle estimate sits 2.9-fold (0.46 log units) above what was measured; the range from low to high includes it.
By their numbers in this assay, from the lowest: compound 1; then compound 4; then compound 3; then compound 2.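

Replacing cyclohexyl with 4,4-difluorocyclohexyl on the carbonyl carbon keeps the six-membered ring, yet this assay still registers the change: a 2.4-fold lower number from compound 3 to compound 4 (0.38 log units; beyond the scatter) is modest but beyond the scatter, so this position responds to fluorine on the ring as well as to a swap of one ring for another. The new group still does not match the 2-methylcyclopropyl group, as a 7.4-fold higher number from compound 1 to compound 4 (0.87 log units; beyond the scatter) shows, while a 9.1-fold lower number from compound 2 to compound 4 (0.96 log units; beyond the scatter) places it well clear of the 3-methoxycyclobutyl group. Nothing available here accounts for this shift.

The compounds shown leave open whether a hydroxyl or a trifluoromethyl group on the cyclohexyl ring would move the number the same way as the two fluorines. They also leave open whether a difluorocyclopropyl group would keep the low number of compound 1 or shift it further.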